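The source may hold more compounds than are shown below. What is called first, only, known or untested is meant among the compounds shown, and "the series" means these compounds.

Measured compounds:
- compound 1 `Cc1cc(O)c(C(=O)/C=C/c2ccc(Cl)cc2)c(-c2ccccc2)c1C(=O)/C=C/c1ccc(Cl)cc1`, in an ADME assay on HEK293 cells (Homo sapiens) for cytotoxicity, read by MTT assay, with a stated time of 24 h (a higher number here means a weaker inhibitor, a lower number a stronger inhibitor), compound 1 gives 10000 nM
- compound 2 `COc1ccc(/C=C/C(=O)c2c(C)cc(O)c(C(=O)/C=C/c3ccc(OC)cc3)c2-c2ccc(OCc3ccccc3)cc2)cc1`, compound 2 gives 28000 nM
- compound 3 `Cc1cc(O)c(C(=O)/C=C/c2ccccc2)c(-c2ccc(Cl)cc2)c1C(=O)/C=C/c1ccccc1`, compound 3 gives 5000 nM

Compound 1 stands second highest of the three numbers. Its nearest neighbour is compound 3, whose number is within the scatter of it, so no order between compound 1 and compound 3 can be stated. Compound 2 lies furthest away, with a higher number that is beyond the scatter. Among the measured compounds shown here, no pair of measured compounds differs in only one place, so no single-change step is available from the series itself.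

Compound 4 `Cc1cc(O)c(C(=O)/C=C/c2ccc(Cl)cc2)c(-c2ccc(Br)cc2)c1C(=O)/C=C/c1ccc(Cl)cc1` is not yet measured. It differs from compound 1 by bromo in place of hydrogen on an aromatic carbon. For the measured compounds named here, nothing among the measured compounds isolates this change, so the expectation rests on the position of compound 1 alone. No step beyond the scatter is expected in this assay in either direction. Compound 4 is estimated at 8000 nM, with a range from 3000 nM to 22000 nM. The expected step is a 1.3-fold lower number from compound 1 to compound 4 (0.10 log units; within the scatter), a small shift that stays within the scatter.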

Compound 4, half-maximal inhibitory concentration: 25000 nM
Beside the measured number, compound 4's estimate is 3.1-fold (0.49 log units) below it; the measured number lies above the stated range.
By their numbers in this assay, from the lowest: compounds 3 and 1 (each within the scatter of the next); then compounds 4 and 2 (each within the scatter of the next).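

In this assay, bromo in place of hydrogen on an aromatic carbon, para to a large group, gives a 2.5-fold higher number from compound 1 to compound 4 (0.40 log units; beyond the scatter), the first single-change step available in the series. This place on the core of compound 1 therefore responds to substitution: one added heavy atom moves the number upward, towards a weaker inhibitor. No measurement at hand explains this step.

Going by these compounds, it remains open whether the higher number is specific to bromo or would also appear with another group at this place, such as an amine or a carboxylic acid. On these data alone, compound 2 and compound 3 differ from compound 1 in more than one place, so the size of this step on a core without the chloro groups of compound 1 also remains unknown.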